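The source may hold more compounds than are shown below. What is called first, only, known or untested is meant among the compounds shown, and "the series" means these compounds.

The study compares four ureas built on two cores. Compound 1 `Cc1ccccc1OS(=O)(=O)c1cccc(NC(=O)NCCCCl)c1` and compound 2 `CCc1ccccc1OS(=O)(=O)c1cccc(NC(=O)NCCCCl)c1` share one core; compound 3 `Cc1ccccc1NS(=O)(=O)c1ccc(NC(=O)NCCCCl)cc1` and compound 4 `CCc1ccccc1NS(=O)(=O)c1ccc(NC(=O)NCCCCl)cc1` share another, and the difference between the two cores is not broken down here. In a functional assay on HT-29 cells (Homo sapiens) for cytotoxicity, read by sulforhodamine B assay, with a stated time of 48 h (on this read-out higher numbers stand for weaker inhibition and lower numbers for stronger inhibition), compound 1 gives 21000 nM, and in this assay compound 2 gives 23000 nM. The change from compound 1 to compound 2 is methyl in place of hydrogen on a saturated chain carbon bound to an aromatic carbon, and it made a 1.1-fold higher number from compound 1 to compound 2 (0.04 log units; within the scatter). In this assay compound 3 gives 64000 nM, the highest of the three numbers, beyond the scatter from both compound 1 and compound 2. Compound 4 carries the same change on the second core: methyl in place of hydrogen on a saturated chain carbon bound to an aromatic carbon. Because a 1.1-fold higher number from compound 1 to compound 2 (0.04 log units; within the scatter) stayed within the scatter on the first core, a similarly small step is expected on the second, a 1.1-fold higher number from compound 3 to compound 4 (0.04 log units; within the scatter). On that basis compound 4 is expected to give about 70000 nM in this assay, most likely between 35000 nM and 140000 nM.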

Compound 4, half-maximal inhibitory concentration: > 200000 nM
Compound 4: a limit, no number; the forecaster's own chance of this, stated with the estimate: 5%; middle value at least 2.8-fold (0.45 log units) from the limit.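

In this assay compound 4 gives > 200000 nM as a limit of the assay and not a number: the limit of > 200000 nM in this assay, at which 1 of the 4 values shown sits. The step reads an at least 3.1-fold higher number from compound 3 to compound 4 (0.49 log units; beyond the scatter) and so, in this pair of cores, methyl in place of hydrogen on a saturated chain carbon bound to an aromatic carbon did not carry over with the same size from the core of compound 1 to the core of compound 3: the same change on two cores in this assay, a 1.1-fold higher number (0.04 log units; within the scatter) from compound 1 to compound 2 and an at least 3.1-fold higher number (0.49 log units; beyond the scatter) from compound 3 to compound 4, at least 2.8-fold (0.45 log units) apart, beyond the scatter of two such steps. Going by these compounds alone, this does not give the full size of the step on the second core, and with only one pair on each core it sets no rule for the series and does not say which feature of the cores goes with the gap.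

The compounds shown leave open how a propyl or a methoxy group in place of the ethyl would read on either core. They also leave open which of the differences between the two cores goes with the larger step.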